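Amine variation on the ether side chain in an antiproliferative series

The source may report more compounds than this note shows. Statements on the series, on what has been measured and on what is new or still open speak of the compounds shown alone.

Measured compounds:
compound 1, `CC(C)=CCc1cc(C(=O)Nc2cc3ccc(OCC4CCCN(C)C4)c(C)c3oc2=O)ccc1O`, 2640 nM
compound 2, `CC(C)=CCc1cc(C(=O)Nc2cc3ccc(OCCCN4CCCC4)c(C)c3oc2=O)ccc1O`, 990 nM
compound 3, `CC(C)=CCc1cc(C(=O)Nc2cc3ccc(OCCCN(C)C4CCCCC4)c(C)c3oc2=O)ccc1O`, 1080 nM

In a functional assay on MCF7 cells (Homo sapiens) for antiproliferative activity (on this read-out higher numbers stand for weaker inhibition and lower numbers for stronger inhibition), compound 2 gives the lowest of the three numbers, although compound 3 stands within the scatter of it, so neither can be called the stronger of the two. The two steps that reach beyond the scatter both start from compound 1: a 2.7-fold lower number from compound 1 to compound 2 (0.43 log units; beyond the scatter) and a 2.4-fold lower number from compound 1 to compound 3 (0.39 log units; beyond the scatter), each replacing 1-methylpiperidin-3-yl with an open chain carrying an amine. Between the two chain amines themselves the step is a 1.1-fold higher number from compound 2 to compound 3 (0.04 log units; within the scatter).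

Compound 4, `CC(C)=CCc1cc(C(=O)Nc2cc3ccc(OCCCN[C@@H]4C[C@H]5CC[C@@H]4C5)c(C)c3oc2=O)ccc1O`, has not yet been measured. The change from compound 2 is a group of 8 heavy atoms (7 carbon, 1 nitrogen; 2 five-membered non-aromatic rings of carbon only) in place of a group of 5 heavy atoms (4 carbon, 1 nitrogen; one five-membered non-aromatic ring with 1 hetero atom), on a saturated chain carbon, three bonds along the chain from an oxygen on an aromatic ring. For the measured compounds named here, the step that bears on it most directly is the one from compound 2 to compound 3, where a different amine at the same place left the number within the scatter; the steps from compound 1 changed the chain itself and are less comparable. Compound 4 is therefore expected to land close to compound 2, with a step of a 1.1-fold higher number from compound 2 to compound 4 (0.05 log units; within the scatter), not beyond the scatter in either direction. The estimate for compound 4 is 1100 nM, within a range from 500 nM to 2500 nM.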

Compound 4, half-maximal inhibitory concentration: 1030 nM
Beside the measured number, compound 4's estimate is 1.1-fold (0.03 log units) above it, within the range that was stated.
By their numbers in this assay, from the lowest: compounds 2, 4 and 3 (each within the scatter of the next); then compound 1.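

At the saturated chain carbon, three bonds along the chain from an oxygen on an aromatic ring, the group with 2 five-membered non-aromatic rings of carbon only brings 1 hydrogen-bond donor and 3 defined stereocentres, yet in this assay the result is a 1.0-fold higher number from compound 2 to compound 4 (0.02 log units; within the scatter) and a 1.0-fold lower number from compound 3 to compound 4 (0.02 log units; within the scatter), so three differently built amine groups at this place now cannot be told apart in this assay. The step of a 2.6-fold lower number from compound 1 to compound 4 (0.41 log units; beyond the scatter) is, like the two earlier steps from compound 1, beyond the scatter, which leaves compound 1 as the only one of the four set apart from the rest. Nothing measured here accounts for the lack of separation among compounds 2, 3 and 4.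

The compounds shown leave open whether this tolerance extends to a morpholin-4-yl group, a carboxylic acid or a longer chain between the oxygen and the amine. They also leave open whether the mirror-image form of the group in compound 4, or a methyl group on its amine nitrogen, would stay within the scatter of compound 4.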